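Swapping the trifluoromethyl ring for a chloro-methyl ring

This account rests on a few compounds, and the source may have more. Where it says the series, first, only, none or still open, it means among the compounds named here.

Among the measured compounds shown here, in an assay on HEK293 cells for activation of Kir3.1/Kir3.2 (Homo sapiens), read by thallium flux (a higher number here means that more compound is needed for the effect, a lower number that less compound is needed), compound 2 `Cc1cc(NC(=O)Cn2nnc(-c3cccc(C(F)(F)F)c3)n2)n(C2CCCCC2)n1` gives 183 nM, the lowest of the two numbers measured so far, while compound 1 `Cc1cc(NC(=O)Cn2nnc(-c3ccc(Cl)c(Cl)c3)n2)n(C2CCCCC2)n1` gives 1220 nM. For the measured compounds named here, the only measured step, a 6.7-fold lower number from compound 1 to compound 2 (0.82 log units; beyond the scatter), concerns the very ring that now changes again. Compound 3 `Cc1cc(NC(=O)Cn2nnc(-c3ccc(Cl)c(C)c3)n2)n(C2CCCCC2)n1` differs from compound 2 in one place: 4-chloro-3-methylphenyl in place of 3-(trifluoromethyl)phenyl on an aromatic carbon. A move back toward a higher number is expected, because compound 1 with its chlorinated ring gives 1220 nM. Compound 3 is therefore estimated at 650 nM, within 250 nM to 1800 nM, a step of a 3.6-fold higher number from compound 2 to compound 3 (0.55 log units; beyond the scatter).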

Compound 3, half-maximal effective concentration: 712 nM
Compound 3: the middle estimate sits 1.1-fold (0.04 log units) below what was measured; measured number inside the range.
By their numbers in this assay, from the lowest: compound 2; then compounds 3 and 1 (each within the scatter of the next).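

In this assay, 4-chloro-3-methylphenyl on this aromatic carbon does not match 3-(trifluoromethyl)phenyl, with a 3.9-fold higher number from compound 2 to compound 3 (0.59 log units; beyond the scatter) as the step. Methyl in place of chloro on the ring makes little measurable difference, with a 1.7-fold lower number from compound 1 to compound 3 (0.23 log units; within the scatter) as the step, so among these rings only compound 2 stands apart. No evidence here explains this result. Still open, going by these compounds, is whether a phenyl ring bearing a nitrile or a methoxy group in place of trifluoromethyl would give a number as low as that of compound 2.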